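The source may hold more compounds than are shown below. What is called first, only, known or untested is meant among the compounds shown, and "the series" means these compounds.

Measured so far in a functional assay on SiHa cells (Homo sapiens) for antiproliferative activity, read by CCK-8 assay, with a stated time of 72 h; on this read-out higher numbers stand for weaker inhibition and lower numbers for stronger inhibition:
- compound 1 `COc1ccc(-c2cncnc2-c2cc(OC)c(OC)c(OC)c2)cc1`: 2850 nM
- compound 2 `CCOC(=O)Oc1cc(-c2cncnc2-c2cc(OC)c(OC)c(OC)c2)ccc1OC`: 1890 nM
- compound 3 `COc1ccc(-c2cncnc2-c2cc(OC)c(OC)c(OC)c2)cc1F`: 3340 nM

Repeated measurements of one compound never agree exactly, so small differences in this assay carry no meaning. That decides where compound 1 stands: it cannot be told apart from either of the other two compounds. The data show a 1.5-fold lower number from compound 1 to compound 2 (0.18 log units; within the scatter) and a 1.2-fold higher number from compound 1 to compound 3 (0.07 log units; within the scatter). The remaining pair, a 1.8-fold higher number from compound 2 to compound 3 (0.25 log units; within the scatter), gives the same picture.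

The next compound is compound 4 `COc1cc(-c2ncncc2-c2ccc(OCC(F)(F)F)cc2)cc(OC)c1OC`. The structural change from compound 1 is trifluoromethyl in place of hydrogen on a saturated chain carbon bound to an oxygen on an aromatic ring. In words, trifluoromethyl replaces hydrogen on a saturated chain carbon bound to an oxygen on an aromatic ring, which turns methoxy into 2,2,2-trifluoroethoxy.

Among the compounds with values here, no measured compound carries a change at this place, so the evidence is indirect. Within the data shown here, the only guides are the two changes on an aromatic carbon, and neither moved the number beyond the scatter. These data therefore give no reason to expect a direction, and no shift beyond the scatter is expected. The estimated step is a 1.1-fold higher number from compound 1 to compound 4 (0.02 log units; within the scatter). For compound 4 the expected value is 3000 nM, with an estimated range of 1300 nM to 7000 nM.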

Compound 4, half-maximal inhibitory concentration: 33300 nM
Compound 4: middle estimate off by 11-fold (1.05 log units), on the low side, outside the stated range (above it).
By their numbers in this assay, from the lowest: compounds 2, 1 and 3 (each within the scatter of the next); then compound 4.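

In this assay, this methoxy group turns out to be a place where a small change matters: turning it into 2,2,2-trifluoroethoxy gives a 12-fold higher number from compound 1 to compound 4 (1.07 log units; beyond the scatter). Compound 4 thus carries the first single change in this set to move the number beyond the scatter, whereas the two changes on an aromatic carbon shown earlier did not, and the move is towards weaker inhibition. It also shows that trifluoromethyl, with its 4 heavy atoms, is not tolerated on this saturated chain carbon as hydrogen is in this cell assay, although nothing measured here explains the loss.

The compounds shown leave open whether this step belongs to the fluorine atoms or simply to the extra carbon, and a plain ethoxy group at this place would separate the two. Also open, from the compounds shown here alone, is how a longer chain such as propoxy, or a hydroxy group in place of the methoxy group, would read in the same assay.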